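Ester in place of acid on a linked phenyl

This account rests on a few compounds, and the source may have more. Where it says the series, first, only, none or still open, it means among the compounds named here.

In an assay on HEK293 cells for positive allosteric modulation of metabotropic glutamate receptor 2 (Rattus norvegicus), read by thallium flux, with a stated time of 2.5 min (on this read-out lower numbers stand for smaller maximal responses and higher numbers for larger maximal responses), compound 3, with the structure `Cc1c(OCCCCOc2cccc(C(=O)O)c2)ccc(C(=O)CC(C)C)c1O`, reaches 84.5%. That is the second highest of the three values measured: compound 2, whose structure is `COc1ccc(C(=O)O)cc1OCCCCOc1ccc(C(=O)CC(C)C)c(O)c1C`, gives 89.7%, and compound 1, whose structure is `Cc1c(OCCCCOc2cccc(C(=O)O)c2)ccc(C(=O)CC(C)C)c1C`, gives 12.1%. The step of a number 5.2 percentage points lower from compound 2 to compound 3 (within the scatter) lies within the scatter, whereas the step of a number 72.4 percentage points higher from compound 1 to compound 3 (beyond the scatter) is large and lies well beyond it.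

Compound 4 has the structure `COC(=O)c1ccc(OCCCCOc2ccc(C(=O)CC(C)C)c(O)c2C)cc1`. It differs from compound 3 by 4-(methoxycarbonyl)phenyl in place of 3-carboxyphenyl on an oxygen on a saturated carbon. Among the measured compounds shown here, the two measured steps concern the other end of the molecule, hydroxy in place of methyl and hydrogen in place of methoxy, so neither of them bears on the carboxyphenyl part, and no measured pair shows what replacing the acid with an ester does here. The expectation therefore rests on little: the change removes the only hydrogen-bond donor of the leaving group, and a step of uncertain size is expected, more likely downward than upward.

Compound 4 is expected to give 70% in this assay, within a range from 35% to 100%. That estimate corresponds to an expected step of a number 14.5 percentage points lower from compound 3 to compound 4 (beyond the scatter).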

Compound 4, largest response reached (reported as percent of maximum), in percent of the reference or control that the assay uses: 16.4%
Estimate against measurement, compound 4: 53.6 percentage points above; the measured number lies below the stated range.
By their numbers in this assay, from the lowest: compounds 1 and 4 (each within the scatter of the next); then compounds 3 and 2 (each within the scatter of the next).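

In this assay, among the compounds shown here, a number 68.1 percentage points lower from compound 3 to compound 4 (beyond the scatter) shows that the maximal response depends strongly on the group at this end of the molecule, a dependence that the earlier steps, all at the other end, could not reveal. For the compounds shown here, compound 4 keeps the hydroxy introduced in a number 72.4 percentage points higher from compound 1 to compound 3 (beyond the scatter), so that hydroxy does not secure a high response on its own, and the single step also combines two differences, since the free acid becomes a methyl ester and the substituent moves from the 3-position to the 4-position named in the two groups, and it cannot say which of them counts. Nothing available explains the fall in response.

Going by these compounds, it remains open whether the response follows the free carboxylic acid or its place on the ring, a question that a 4-carboxyphenyl or a 3-(methoxycarbonyl)phenyl group on the same oxygen would separate. On these data alone, it is also open whether a primary carboxamide or a tetrazole at this end would give a response close to that of compound 3, at 84.5%.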